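From isopropyl to 2-carboxyethyl: what happens to inhibition?

The source may report more compounds than this note shows. Statements on the series, on what has been measured and on what is new or still open speak of the compounds shown alone.

Three related compounds have been tested in a functional assay (aorta) for inhibition, with Rattus norvegicus as the target (a lower number here means a stronger inhibitor, a higher number a weaker inhibitor), where each result is the concentration needed to reach the stated inhibition. In this assay compound 1 `C/N=C(\S)[C@]1(c2cnc3ccccc3c2)CCCC[S+]1[O-]` gives 60 nM. Compound 3 `CC(C)/N=C(\S)[C@]1(c2cccnc2)CCCC[S+]1[O-]` gives 10000 nM. That is the higher of the two exact numbers available, and its gap to compound 1 lies beyond the usual scatter, so compound 3 is the weaker inhibitor of this pair.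

Compound 4 `O=C(O)CC/N=C(\S)[C@]1(c2cccnc2)CCCC[S+]1[O-]` has not yet been measured. It differs from compound 3 in a single place, with 2-carboxyethyl in place of isopropyl on a double-bonded nitrogen. Among the compounds with values here, no measured pair shows this change directly, so the expectation rests on thin support.

The nearest clue is compound 2 `C/N=C(\S)[C@]1(c2cccc(C(=O)O)c2)CCCC[S+]1[O-]`, which also carries a carboxyl group, although elsewhere on the molecule, and whose > 30000 nM is a limit of the assay and not a number. On that single comparison, the expected step is a 3.0-fold higher number from compound 3 to compound 4 (0.48 log units; beyond the scatter), towards weaker inhibition, and the assay may report only a limit. For compound 4 the estimated value is 30000 nM, with an expected range from 8000 nM to 100000 nM.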

Compound 4, concentration for 90% inhibition: > 30000 nM
Compound 4: a limit, no number; the forecaster's own chance of this, stated with the estimate: 60%; the middle value lies on the limit itself.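

Within the data shown here, this is the first direct reading of a change at this position, the group on the double-bonded nitrogen, with the rest of compound 3 left as it is. In this assay, replacing isopropyl with 2-carboxyethyl gives an at least 3.0-fold higher number from compound 3 to compound 4 (0.47 log units; beyond the scatter), so this larger group, which brings a hydrogen-bond donor and acceptor, does not restore the inhibition that compound 3 already largely lacks. Compound 4 gives > 30000 nM, which is a limit of the assay and not a number, and the step can be stated only as a minimum because of that limit: the limit of > 30000 nM in this assay, at which 2 of the 4 values shown sit.

Going by these compounds, the true size of the step therefore stays unknown, and a single change cannot show whether the result belongs to the carboxylic acid itself or to the chain that carries it; a plain propyl chain or a chain ending in an amine on this nitrogen would help to separate the two. Compound 1 differs from compound 3 in more than one place, so the compounds shown also leave open how much of its much lower number comes from the group on this nitrogen.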